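The compounds below may be only part of what the source reports. "The series", "measured", "known", "first", "only" and "open" are said of these compounds alone.

Measured so far:
compound 1, `N#CC1=C(N)OC(c2c[nH]c3ccccc23)=C(C#N)C1c1ccccc1F` — a functional assay, tested at 200 ug/mL; on this read-out higher numbers stand for a stronger effect at the one concentration tested and lower numbers for a weaker effect: "not active" (no number reported)
compound 2, `N#CC1=C(N)OC(c2c[nH]c3ccccc23)=C(C#N)C1c1ccc(Br)cc1` — 10.6%

Among the compounds with values here, compound 2 is the only entry in this assay that carries a number; compound 1 stands beside it without one, so no step between measured compounds can be drawn. Compound 3, `N#CC1=C(N)OC(c2c[nH]c3ccccc23)=C(C#N)C1c1ccc2ccccc2c1`, differs from compound 2 by naphthalen-2-yl in place of 4-bromophenyl on a saturated ring carbon. Within the data shown here, with no comparable step, the expected change from compound 2 to compound 3 in this assay is a number 2.4 percentage points higher from compound 2 to compound 3 (within the scatter), a step estimated to stay within the usual scatter. For compound 3 in this assay the estimate is 13%, with a range from 0% to 30%.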

Compound 3, a percentage reported as activity, at one concentration (the size of the read-out at that concentration, not a potency): "not active" (no number reported)
No number was reported for compound 3; the estimate stays without a comparison.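

No step can be read from compound 2 to compound 3 in this assay, as compound 3 carries no number. The compounds shown leave open how naphthalen-2-yl compares numerically with 4-bromophenyl on this read-out. Nothing shown bears on an explanation for this result.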